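Triazole series, cell growth inhibition: compound 4 from compound 3

This account rests on a few compounds, and the source may have more. Where it says the series, first, only, none or still open, it means among the compounds named here.

Three compounds of the shared core have numbers in a functional assay on HCT-116 cells (Homo sapiens) for inhibition, read by MTT assay, with a stated time of 2 days, tested at 10 uM; on this read-out higher numbers stand for more inhibition at the one concentration tested (going by the name of the read-out) and lower numbers for less inhibition. Compound 1 `COC(=O)c1cc(-n2cc(-c3cc(O)ccc3O)nn2)ccc1O` gives 15%. Compound 2 `COc1cc(OC)cc(-c2cn(-c3ccc(O)c(C(=O)OCCCc4ccccc4)c3)nn2)c1` gives 19%. Compound 3 `COc1ccccc1-c1cn(-c2ccc(O)c(C(=O)OCCCc3ccccc3)c2)nn1` gives 7%, the lowest of the three numbers; the gap to compound 1 lies within the scatter, the gap to compound 2 beyond it. Among the compounds with values here, the one step measured between compounds that differ in a single place is a number 12 percentage points lower from compound 2 to compound 3 (beyond the scatter).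

Compound 4 `O=C(OCCCc1ccccc1)c1cc(-n2cc(-c3cc(O)ccc3O)nn2)ccc1O` is not yet measured. It differs from compound 3 in one place: 2,5-dihydroxyphenyl in place of 2-methoxyphenyl on an aromatic carbon. Within the data shown here, no measured step covers this exchange. Compound 1 carries the same 2,5-dihydroxyphenyl as compound 4 and differs from it only in the ester; compound 1 and compound 3 are within the scatter of each other, so their values alone do not point to a direction. The step from compound 2 to compound 3 shows that exchanging the group on this aromatic carbon can move the read-out by a modest amount, which sets the expected scale.

Compound 4 is therefore expected to land near the other two numbers, with a number 7 percentage points higher from compound 3 to compound 4 (within the scatter) as the expected step from compound 3. The estimate for compound 4 is 14%, within 4% to 26%.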

Compound 4, a percentage reported as inhibition, at one concentration (the size of the read-out at that concentration, not a potency): 39%
The estimate for compound 4 lay 25 percentage points below the measured number; measured number outside the range, above it.
By their numbers in this assay, from the lowest: compounds 3, 1 and 2 (each within the scatter of the next, the first and the last beyond it); then compound 4.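

In this assay, the group on the aromatic carbon of the five-membered ring can raise the number as well as lower it: 2,5-dihydroxyphenyl gives a number 32 percentage points higher from compound 3 to compound 4 (beyond the scatter) against 2-methoxyphenyl, and a number 20 percentage points higher from compound 2 to compound 4 (beyond the scatter) against 3,5-dimethoxyphenyl. The ester also counts when this group is held fixed, with phenethyl in place of hydrogen on the saturated chain carbon giving a number 24 percentage points higher from compound 1 to compound 4 (beyond the scatter), so among the four compounds only compound 4 combines the 2,5-dihydroxyphenyl with the phenylpropyl ester, and it alone gives a number well clear of the others. Nothing available explains why either exchange raises the number.

Still open, as far as these compounds go, is whether both hydroxyl groups are needed for the step or one of them accounts for it, which a 2-hydroxyphenyl or 3-hydroxyphenyl analogue of compound 4 would separate. Also open, from the compounds shown here alone, are how an aminophenyl group on the same carbon or a carboxylic acid in place of the ester would read, and, with every number taken at a single concentration, how potent compound 4 is.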